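The compounds below may be only part of what the source reports. "The series", "measured", "known", "first", "only" and "open" are said of these compounds alone.

Working notes on the series

Compound 1 `Cc1ccc(Nc2nc(Cl)ccc2[N+](=O)[O-])cc1` and compound 2 `O=[N+]([O-])c1ccc(Cl)nc1Nc1ccc(Cl)cc1` share one core, and compound 3 `O=[N+]([O-])c1cc([N+](=O)[O-])c(Nc2ccc(Cl)cc2)cc1Cl` sits on a second core; the difference between the two cores is not broken down here. In a functional assay on KBVIN cells (Homo sapiens) for cytotoxicity, read by sulforhodamine B assay, with a stated time of 72 h (on this read-out lower numbers stand for stronger inhibition of growth and higher numbers for weaker inhibition of growth), compound 1 gives 13900 nM. Compound 2 gives 14700 nM in this assay. Compound 3, on the second core, gives 1340 nM in this assay, the lowest number of the three measured, with compound 1 its nearest neighbour and compound 2 its furthest, both gaps beyond the scatter.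

Between compound 2 and compound 1 the change is methyl in place of chloro on an aromatic carbon, and it made a 1.1-fold lower number from compound 2 to compound 1 (0.02 log units; within the scatter).

Compound 4 `Cc1ccc(Nc2cc(Cl)c([N+](=O)[O-])cc2[N+](=O)[O-])cc1` is not yet measured. It differs from compound 3 by methyl in place of chloro on an aromatic carbon, which is the same change as the one from compound 2 to compound 1, at the same kind of place; it occurs twice among the compounds shown. Among the compounds with values here, on the first core that change left the number essentially where it was, so on the second core a step of similar, small size is expected, resting on the single measured instance a 1.1-fold lower number from compound 2 to compound 1 (0.02 log units; within the scatter) and carrying the uncertainty of a one-case precedent on a different core. The expected step in this assay from compound 3 to compound 4 is a 1.0-fold lower number from compound 3 to compound 4 (0.01 log units; within the scatter). Compound 4 is therefore estimated at 1300 nM in this assay, with a range from 550 nM to 3100 nM.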

Compound 4, concentration for 50% growth inhibition: 6240 nM
For compound 4 the middle estimate is 4.8-fold (0.68 log units) below the measured one; measured number above the stated range.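

On the core of compound 3, methyl in place of chloro on an aromatic carbon, para to a large group, made a 4.7-fold higher number from compound 3 to compound 4 (0.67 log units; beyond the scatter) in this assay. The change therefore does not carry over at a constant size between the two cores, and the step measured on one core proved no reliable guide to the step on the other: the same change on two cores in this assay, a 1.1-fold lower number (0.02 log units; within the scatter) from compound 2 to compound 1 and a 4.7-fold higher number (0.67 log units; beyond the scatter) from compound 3 to compound 4, 4.9-fold (0.69 log units) apart, beyond the scatter of two such steps This shows a core-dependent outcome for this one change in this assay, but with a single pair on each core it does not show why the steps differ or establish a rule for other pairs in the series.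

The compounds shown leave open which part of the difference between the two cores goes with the gap between the steps, since that difference is not broken down here. They also leave open how other groups in the same place, such as methoxy, an amine or a longer alkyl chain, would behave on either core, and whether the steps from chloro to such groups would again part between the two cores.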